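Bis-benzimidazole series: methylphenyl isomers and a piperazine swap

This account rests on a few compounds, and the source may have more. Where it says the series, first, only, none or still open, it means among the compounds named here.

Measured compounds, with their values in a functional assay on RPMI 8402 cells (Homo sapiens) for cytotoxicity; on this read-out higher numbers stand for weaker inhibition and lower numbers for stronger inhibition:
- compound 1 `Cc1ccccc1-c1nc2cc(-c3nc4cc(C(N)=O)ccc4[nH]3)ccc2[nH]1`: 8200 nM
- compound 2 `Cc1cccc(-c2nc3cc(-c4nc5cc(C(N)=O)ccc5[nH]4)ccc3[nH]2)c1`: 8200 nM
- compound 3 `Cc1ccc(-c2nc3cc(-c4nc5cc(C(N)=O)ccc5[nH]4)ccc3[nH]2)cc1`: > 25000 nM, which is a limit of the assay rather than a number

Compound 1 stands level with compound 2 at the digits given; the step of no change at the digits printed from compound 1 to compound 2 (within the scatter) lies within the scatter. The step of an at least 3.0-fold higher number from compound 1 to compound 3 (0.48 log units; beyond the scatter) and the step of an at least 3.0-fold higher number from compound 2 to compound 3 (0.48 log units; beyond the scatter) both go beyond the scatter, but for compound 3 only a limit is known (the limit of > 25000 nM in this assay, at which 1 of the 3 values shown sits), so the size of those steps is a lower bound only.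

Compound 4 `Cc1ccccc1-c1nc2cc(-c3nc4cc(N5CCN(C)CC5)ccc4[nH]3)ccc2[nH]1` differs from compound 1 in one place: 4-methylpiperazin-1-yl in place of carbamoyl on an aromatic carbon. Among the measured compounds shown here, all three measured steps concern the position of the methyl on the phenyl ring at the other end of the shared core; none of them touches the carbamoyl position, so no measured step bears on this change. The expectation for compound 4 therefore rests on the value of compound 1 alone, with a wide range to both sides. In this assay compound 4 is estimated at 6000 nM, between 1500 nM and 25000 nM, and the expected step of a 1.4-fold lower number from compound 1 to compound 4 (0.14 log units; within the scatter) is within the scatter.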

Compound 4, half-maximal inhibitory concentration: 590 nM
Estimate against measurement, compound 4: 10-fold (1.01 log units) above, and the stated range ends above it.
By their numbers in this assay, from the lowest: compound 4; then compounds 1 and 2 (each within the scatter of the next). At a limit, above all of these: compound 3.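

In this assay, setting 4-methylpiperazin-1-yl in place of carbamoyl gives a 14-fold lower number from compound 1 to compound 4 (1.14 log units; beyond the scatter) and is a large step, well beyond the scatter. Among the compounds shown here, this position therefore responds strongly, whereas moving the methyl around the phenyl ring at the other end of the shared core gave no step to a lower number. The change alters several things at once, bringing in a six-membered non-aromatic ring and more heavy atoms while removing the hydrogen-bond donor of the carbamoyl, and no measurement shown separates these features or accounts for the step.

Going by these compounds, whether the piperazine ring itself matters remains open: an unsubstituted piperazine, an open-chain amine such as a dimethylaminoethyl group, or a carboxylic acid at the same position would help to separate the ring, the terminal methyl and the amine nitrogen. On these data alone, it is also open whether the same swap would give a comparable step on the 3-methylphenyl and 4-methylphenyl compounds, compound 2 and compound 3.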